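The source may hold more compounds than are shown below. What is called first, only, known or untested is meant among the compounds shown, and "the series" means these compounds.

Compound 1 `c1ccc(-c2c[nH]c(-c3cccnc3)n2)cc1`: 4.7%
Compound 2 `c1ccc(-c2c[nH]c(-c3ccco3)n2)cc1`: 2.7%

Both compounds share a core built from a five-membered aromatic ring with two nitrogen atoms that carries a phenyl group and a second aromatic ring. In an in vitro assay on HEK293 cells for inhibition of sodium channel protein type 2 subunit alpha (Homo sapiens), read by patch clamp, tested at 10 uM (on this read-out higher numbers stand for a stronger effect at the one concentration tested and lower numbers for a weaker effect), compound 1 gives 4.7%, and compound 2 gives 2.7%. The two numbers lie within the usual scatter of each other, so compound 2 cannot be told apart from compound 1 on this read-out; both show little effect at the single concentration tested.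

Compound 3 `c1ccc(-c2c[nH]c(-c3ccoc3)n2)cc1` is the next structure to be examined. It keeps the same atoms as compound 2 but joins them differently: furan-3-yl in place of furan-2-yl on an aromatic carbon. Only the point of attachment of the furan ring shifts, furan-3-yl in place of furan-2-yl on an aromatic carbon of the core.

Going by the values given here, no measured pair shows what such a shift does here. Given how small both measured numbers are, the step of a number 1.3 percentage points higher from compound 2 to compound 3 (within the scatter) is expected to be none beyond the scatter. Compound 3 is therefore estimated at 4%, with a range from -5% to 13%.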

Compound 3, a percentage reported as activity, at one concentration (the size of the read-out at that concentration, not a potency): 11.9%
Compound 3: the middle estimate sits 7.9 percentage points below what was measured, and the stated range covers the measured number.
By their numbers in this assay, from the lowest: compounds 2, 1 and 3 (each within the scatter of the next).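

Furan-2-yl and furan-3-yl have the same atoms and the same counts of hydrogen-bond donors and acceptors, so this pair tests only the point of attachment on the aromatic carbon between two ring nitrogen atoms. In this assay, going by these compounds alone, that swap gives a number 9.2 percentage points higher from compound 2 to compound 3 (within the scatter) and so remains inside the ordinary variation between repeated measurements, although it is the first direct reading of a one-place change at this position. Nothing independent of these numbers bears on the result, so what lies behind it stays unexplained.

With only furan and the ring of compound 1 shown on this carbon, it remains unknown whether a clearly different group there, such as an amine, a carboxylic acid or a longer alkyl chain, would move the number beyond that variation. A single tested concentration also gives no potency, so a full concentration series and repeat measurements would be needed to show whether furan-3-yl truly differs from furan-2-yl.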